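A few compounds are considered here, and "the series" means these few. Any claim that something is new, unique, unknown or untested is made for them only; others in the source may bear on it.

Compound 2 `O=C(O)c1ccccc1-c1ccc(CCc2ncc(Cc3cccc(F)c3)[nH]2)cc1` gives the lowest of the three numbers measured in an in vitro functional assay on cells for agonist activity at Bombesin receptor subtype-3 (Homo sapiens), read by luminescence and calcium flux (a higher number here means that more compound is needed for the effect, a lower number that less compound is needed), with a value of 159 nM. The nearest is compound 3 `CCCCc1cnc(C(CCCO)Cc2ccc(-c3ccccc3C(=O)O)cc2)[nH]1`, which gives 1900 nM; the furthest is compound 1 `CCCCc1cnc(CCCc2ccc(-c3ccccc3C(=O)O)cc2)[nH]1`, which gives 5600 nM. Both of those gaps lie beyond the usual scatter, so compound 2 is the most potent of the three. Compound 4 `COc1ccccc1Cc1cnc(CCc2ccc(-c3ccccc3C(=O)O)cc2)[nH]1` differs from it in one place: 2-methoxyphenyl in place of 3-fluorophenyl on a saturated chain carbon bound to an aromatic carbon. No measured pair among these compounds carries the same change, so there is no direct guide to its effect. The step from compound 2 to compound 4 is expected to be small, a modest weakening if anything, a 1.9-fold higher number from compound 2 to compound 4 (0.28 log units; within the scatter). Compound 4 is therefore estimated at 300 nM, within a range from 80 nM to 1200 nM.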

Compound 4, half-maximal effective concentration: 1720 nM
For compound 4 the middle estimate is 5.7-fold (0.76 log units) below the measured one; measured number outside the range, above it.
By their numbers in this assay, from the lowest: compound 2; then compounds 4 and 3 (each within the scatter of the next); then compound 1.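

Replacing 3-fluorobenzyl with 2-methoxybenzyl at this saturated chain carbon gives an 11-fold higher number from compound 2 to compound 4 (1.03 log units; beyond the scatter). This is the first single change shown here, and it reveals that the group at this place can shift the number well beyond the scatter. No measurement here gives a reason for the loss. The change alters both the substituent and its place on the aromatic ring, so the compounds shown cannot separate the two. A 2-fluorobenzyl or 3-methoxybenzyl group would be needed to tell these apart, and an unsubstituted benzyl group would give a plain reference point.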